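The compounds below may be only part of what the source reports. "The series", "measured", "known", "first", "only" and "open" are said of these compounds alone.

Two close relatives of the same core have been measured. Compound 1 `Cc1cc(Br)ccc1NC(=O)CN1CCC(c2cccc[n+]2[O-])CC1` carries a 4-bromo-2-methylphenyl on its amide-type nitrogen, and in a functional assay on HEK293 cells for agonist activity at D(4) dopamine receptor (Homo sapiens), read by FLIPR (on this read-out lower numbers stand for an effect already at smaller amounts and higher numbers for an effect only at larger amounts of compound), compound 1 gives 66 nM. Compound 2 `O=C(CN1CCC(c2cccc[n+]2[O-])CC1)Nc1cccc(Cl)c1` carries a 3-chlorophenyl there instead, and in this assay compound 2 gives 62 nM. Within the data shown here, of the two numbers the one for compound 2 is the lower, but the step of a 1.1-fold lower number from compound 1 to compound 2 (0.03 log units; within the scatter) places the pair within the scatter, so neither stands apart.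

Compound 3 `Cc1ccc(Cl)cc1NC(=O)CN1CCC(c2cccc[n+]2[O-])CC1` is compound 2 with methyl in place of hydrogen on an aromatic carbon, placed ortho to a large group and para to the chloro group, which turns the ring into 5-chloro-2-methylphenyl. Among the measured compounds shown here, the only step on hand, a 1.1-fold lower number from compound 1 to compound 2 (0.03 log units; within the scatter), exchanges the whole ring, including a methyl that also sits ortho to the large group, without a change beyond the scatter. No step beyond the scatter is expected here either.

Compound 3 is therefore expected to give 60 nM, with a likely range from 25 nM to 150 nM. The expected step is a 1.0-fold lower number from compound 2 to compound 3 (0.01 log units; within the scatter).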

Compound 3, half-maximal effective concentration: 126 nM
Beside the measured number, compound 3's estimate is 2.1-fold (0.32 log units) below it, and the stated range covers the measured number.
By their numbers in this assay, from the lowest: compounds 2, 1 and 3 (each within the scatter of the next, the first and the last beyond it).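

In this assay, placing one methyl on an aromatic carbon of the ring of compound 2, ortho to a large group and para to the chloro group, gives a 2.0-fold higher number from compound 2 to compound 3 (0.31 log units; beyond the scatter) and so makes the only step among these compounds that passes beyond the usual scatter, though modestly. Measured against the other ring that carries a methyl, the picture is different: a 1.9-fold higher number from compound 1 to compound 3 (0.28 log units; within the scatter) stays within the scatter, so 5-chloro-2-methylphenyl and 4-bromo-2-methylphenyl cannot be told apart here. Nothing available gives a reason for the step caused by the methyl.

Still open, on these data alone, is whether an ethyl or a methoxy group on this same carbon would shift the number further than methyl does. Also open, as far as these compounds go, is whether methyl gives a similar step on a ring carrying fluoro instead of chloro.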